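Thiophen-3-yl for 3-Chlorophenyl: An Expected Potency Estimate

The source may hold more compounds than are shown below. What is called first, only, known or untested is meant among the compounds shown, and "the series" means these compounds.

Measured so far:
compound 1 `CC1=NC(C)=C(C(=O)O)C(c2ccccc2[N+](=O)[O-])/C1=C(\O)OC/C=C/c1ccccc1` — 31 nM
compound 2 `CC1=NC(C)=C(C(=O)O)C(c2cccc(Cl)c2)/C1=C(\O)OC/C=C/c1ccccc1` — 20 nM

Of the compounds shown here, two have been measured in a functional assay on thoracic aorta for inhibition of Voltage-gated L-type calcium channel (Rattus norvegicus); a lower number here means a stronger inhibitor, a higher number a weaker inhibitor. Compound 1 gives 31 nM, and compound 2 gives 20 nM. Among the measured compounds shown here, compound 2 carries the lowest of the two numbers, but its only neighbour is compound 1, and the step of a 1.6-fold lower number from compound 1 to compound 2 (0.19 log units; within the scatter), so the two cannot be ordered.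

Compound 3 `CC1=NC(C)=C(C(=O)O)C(c2ccsc2)/C1=C(\O)OC/C=C/c1ccccc1` has not yet been measured. It differs from compound 2 by thiophen-3-yl in place of 3-chlorophenyl on a saturated ring carbon. For the measured compounds named here, the only measured step that bears on this change is a 1.6-fold lower number from compound 1 to compound 2 (0.19 log units; within the scatter), an exchange of the group on the same saturated ring carbon; that step stayed within the scatter. Going by the values given here, no measured pair exchanges a six-membered aromatic ring for a five-membered one, so there is no direct precedent for the size of this move. Among the compounds with values here, on the one related step a small change is expected, a 1.8-fold higher number from compound 2 to compound 3 (0.24 log units; within the scatter). Compound 3 is therefore estimated at 35 nM, within a range from 10 nM to 120 nM.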

Compound 3, half-maximal inhibitory concentration: 44 nM
Estimate against measurement, compound 3: 1.3-fold (0.10 log units) below, within the range that was stated.
By their numbers in this assay, from the lowest: compounds 2, 1 and 3 (each within the scatter of the next, the first and the last beyond it).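

In this assay, among the compounds shown here, the saturated ring carbon carries a five-membered aromatic ring with 1 hetero atom as well as the two substituted six-membered aromatic rings, and the first exchange at this position to pass the scatter appears (a 2.2-fold higher number from compound 2 to compound 3 (0.34 log units; beyond the scatter)). That step is only modest, and thiophen-3-yl cannot be separated from 2-nitrophenyl (a 1.4-fold higher number from compound 1 to compound 3 (0.15 log units; within the scatter)), so across these three groups the position spans a narrow band of numbers. No measurement at hand explains why thiophen-3-yl separates from 3-chlorophenyl but not from 2-nitrophenyl.

Left open is how a thiophen-2-yl, a pyridyl or a cyclohexyl group would read on this carbon. Also open, from the compounds shown here alone, is whether the exchange of 3-chlorophenyl for thiophen-3-yl would give a step of similar size if a methyl ester replaced the carboxy group.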